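The source may hold more compounds than are shown below. What is called first, only, known or untested is meant among the compounds shown, and "the series" means these compounds.

Compound 1 `NC(=O)c1sc2nccc(OC3CCOCC3)c2c1N` carries oxan-4-yl on the oxygen attached to its aromatic core. In an ADME assay on microsomes from liver (Rattus norvegicus) for metabolic stability, with a stated time of 30 min (a higher number here means that more of the compound is left, a lower number that less of the compound is left), compound 1 gives 85%, the highest of the three numbers seen here. Compound 2 `Cc1cc(Oc2ccc(CCCC(=O)N(C)C)cc2F)c2c(N)c(C(N)=O)sc2n1` gives 12% in this assay, and compound 3 `Cc1cc(Oc2ccc(CCCC(=O)N(C)C)cc2Cl)c2c(N)c(C(N)=O)sc2n1` gives 11%, both far below compound 1 and beyond the scatter. Among the measured compounds shown here, the only measured step between two compounds that differ in a single place, a number 1 percentage points lower from compound 2 to compound 3 (within the scatter), lies within the scatter and exchanges one halogen for another. Compound 4 `C[C@H]1CCCC[C@@H]1Oc1ccnc2sc(C(N)=O)c(N)c12` differs from compound 1 in one place: 2-methylcyclohexyl in place of oxan-4-yl on an oxygen on an aromatic ring. For the measured compounds named here, no measured pair changes the group on this oxygen alone, so the halogen step does not bear on it. Compounds 2 and 3, which carry a different group on that oxygen but also differ from compound 1 elsewhere, give only a loose hint that a change here can cost much. The expectation for compound 4 is a drop of a number 40 percentage points lower from compound 1 to compound 4 (beyond the scatter). The estimate for compound 4 is 45%, between 15% and 75%.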

Compound 4, percent of the compound remaining: 7%
Compound 4: the middle estimate sits 38 percentage points above what was measured; measured number outside the range, below it.
By their numbers in this assay, from the lowest: compounds 4, 3 and 2 (each within the scatter of the next); then compound 1.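

The pair of compound 1 and compound 4 isolates the group on the oxygen on an aromatic ring: with the rest of the molecule unchanged, 2-methylcyclohexyl in place of oxan-4-yl gives a large step in this assay (a number 78 percentage points lower from compound 1 to compound 4 (beyond the scatter)). The earlier compounds shown here offered only a loose hint here, whereas this pair shows that this one group can by itself decide how much compound is left. The change swaps a ring with one oxygen and no stereocentres for an all-carbon ring with two defined stereocentres, and nothing available explains why the number falls.

Still open, as far as these compounds go, is which part of the change matters: a plain cyclohexyl without the methyl would separate the methyl from the ring oxygen. A piperidin-4-yl, a ring carrying an amine, would show whether another hetero atom at this place behaves like oxan-4-yl.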